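Swapping Propylcarbonyl for Methoxymethyl on a Shared Core

This account rests on a few compounds, and the source may have more. Where it says the series, first, only, none or still open, it means among the compounds named here.

Three related compounds have been tested so far in a functional assay on A549 cells (Homo sapiens) for antiproliferative activity, read by MTT assay, with a stated time of 48 h; a higher number here means a weaker inhibitor, a lower number a stronger inhibitor. Compound 1 `CC(C)=CCC[C@](C)(/C=C/[C@@H](OC(=O)C=C(C)C)[C@](C)(O)/C=C/C(=O)/C=C/N(C)C)CC=O` gives 11200 nM, and its structure differs from the other two in several places. Compound 2 `CC(=O)O[C@@H]1/C=C/[C@@](C)(CCC=C(C)C)C/C=C(/CO)C(=O)/C=C/[C@@]1(C)O` gives 8670 nM, and compound 3 `CCCC(=O)O[C@@H]1/C=C/[C@@](C)(CCC=C(C)C)C/C=C(/CO)C(=O)/C=C/[C@@]1(C)O` gives 4100 nM, the lowest number of the three and so the strongest inhibitor in this small set.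

Compound 4 `COCO[C@@H]1/C=C/[C@@](C)(CCC=C(C)C)C/C=C(/CO)C(=O)/C=C/[C@@]1(C)O` keeps the shared core of compound 3 and changes one group: methoxymethyl in place of propylcarbonyl on an oxygen on a saturated carbon. In words, methoxymethyl takes the place of propylcarbonyl on an oxygen on a saturated carbon.

Among the measured compounds shown here, only one measured step bears on this change. The step of a 2.1-fold lower number from compound 2 to compound 3 (0.33 log units; beyond the scatter) came with ethyl in place of hydrogen on a saturated chain carbon bound to a carbonyl carbon, and it was modest. For the measured compounds named here, the new group is shorter, which partly reverses that lengthening, but it also lacks the carbonyl, and no measured compound shows what losing it does. A modest move towards a higher number in this assay is therefore expected, with real uncertainty either way.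

The estimated change is a 1.7-fold higher number from compound 3 to compound 4 (0.23 log units; within the scatter). Compound 4 is expected at 7000 nM, with an estimated range from 2800 nM to 16000 nM.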

Compound 4, half-maximal inhibitory concentration: > 40000 nM
Compound 4 gave a limit, no number; the forecaster's own chance of this, stated with the estimate: 3%; middle value at least 5.7-fold (0.75 log units) from the limit.
By their numbers in this assay, from the lowest: compound 3; then compounds 2 and 1 (each within the scatter of the next). At a limit, above all of these: compound 4.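

In this assay compound 4 gives only a limit, not a number: the limit of > 40000 nM in this assay, at which 1 of the 4 values shown sits.

Even with that limit, replacing propylcarbonyl with methoxymethyl gives an at least 9.7-fold higher number from compound 3 to compound 4 (0.98 log units; beyond the scatter), and replacing acetyl with methoxymethyl gives an at least 4.6-fold higher number from compound 2 to compound 4 (0.66 log units; beyond the scatter), so both changes on this oxygen raise the number beyond the scatter. Until now the only view of this position was the modest step between two carbonyl-bearing groups, a 2.1-fold lower number from compound 2 to compound 3 (0.33 log units; beyond the scatter), and the new steps show that the group here can matter more than that step suggested, although the limit hides their full size.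

Methoxymethyl differs from acetyl and propylcarbonyl in lacking the carbonyl, but a single compound cannot show whether that absence or some other feature of methoxymethyl accounts for the result. A free hydroxyl, a methyl ether or a longer chain such as pentylcarbonyl on this oxygen would help separate those possibilities and show how far the number follows the length of the group.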